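Shortening the hydroxycarbamoyl chain of compound 2

This account rests on a few compounds, and the source may have more. Where it says the series, first, only, none or still open, it means among the compounds named here.

Values in a functional assay on HepG2 cells (Homo sapiens) for inhibition, read by MTT assay, with a stated time of 72 h; on this read-out lower numbers stand for stronger inhibition and higher numbers for weaker inhibition:
- Compound 1 `Nc1ncnc2c1c(-c1cnc3[nH]ccc3c1)nn2CCCCCCCCC(=O)NO` gives 3050 nM
- Compound 2 `Nc1nc2cc(-c3nn(CCC(=O)NO)c4ncnc(N)c34)ccc2o1` gives > 150000 nM, which is a limit and not a number
- Compound 3 `Nc1ncnc2c1c(-c1cnc3[nH]ccc3c1)nn2CCCCCCC(=O)NO` gives 10300 nM

Compound 2 stands at the limit of > 150000 nM in this assay, at which 1 of the 3 values shown sits. Compound 4 `Nc1nc2cc(-c3nn(CC(=O)NO)c4ncnc(N)c34)ccc2o1` differs from it by hydroxycarbamoyl in place of (hydroxycarbamoyl)methyl on a saturated chain carbon bound to an aromatic nitrogen, so 2-(hydroxycarbamoyl)ethyl becomes (hydroxycarbamoyl)methyl. Among the measured compounds shown here, the one measured chain-shortening step is a 3.4-fold higher number from compound 1 to compound 3 (0.53 log units; beyond the scatter), which is modest but beyond the scatter. The core of compound 1 differs from that of compound 2, so this guide is only indirect. A similarly modest move toward a higher number is therefore expected in this assay, and the assay may again report only a limit. The expected size is a step that the limit leaves unreadable from compound 2 to compound 4. For compound 4 the estimated value is 250000 nM, with an expected range from 150000 nM to 600000 nM.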

Compound 4, half-maximal inhibitory concentration: > 150000 nM
Compound 4: a limit, no number; the forecaster's own chance of this, stated with the estimate: 85%; the middle value is on the limit's open side.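

In this assay compound 4 gives > 150000 nM, which is a limit and not a number. Among the compounds shown here, compound 2 is also reported only as a limit, and no step from compound 2 to compound 4 can be read. The compounds shown leave open whether (hydroxycarbamoyl)methyl and 2-(hydroxycarbamoyl)ethyl differ at all on this read-out.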